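Methoxy on the phenyl of the furan-bearing core

A few compounds are considered here, and "the series" means these few. Any claim that something is new, unique, unknown or untested is made for them only; others in the source may bear on it.

Compound 2 `Nc1nc(-c2ccccc2)nc2sc(-c3ccco3)nc12` gives 15 nM in an assay on CHO cells for displacement of a labelled ligand from adenosine receptor A3 (Homo sapiens), read by scintillation counting, with a stated time of 3 h (on this read-out higher numbers stand for weaker inhibition and lower numbers for stronger inhibition), and stands second highest of the three numbers measured. The phenyl analogue, compound 1 `Nc1nc(-c2ccccc2)nc2sc(-c3ccccc3)nc12`, gives 84 nM in this assay, and the step of a 5.6-fold lower number from compound 1 to compound 2 (0.75 log units; beyond the scatter) is modest. With hydroxymethyl on the phenyl ring of compound 2, compound 3 `Nc1nc(-c2cccc(CO)c2)nc2sc(-c3ccco3)nc12` gives 0.9 nM in this assay, so that the step of a 17-fold lower number from compound 2 to compound 3 (1.22 log units; beyond the scatter) is large.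

Compound 4 `COc1ccc(-c2nc(N)c3nc(-c4ccco4)sc3n2)cc1` has not been measured in this assay. It differs from compound 2 by methoxy in place of hydrogen on an aromatic carbon. Among the measured compounds shown here, of the two measured steps, only the step from compound 2 to compound 3 concerns a substituent on the same phenyl ring, and it was large; the step from compound 1 to compound 2 concerns the other ring and bears little on this change. Methoxy is a different group from hydroxymethyl, so the large gain seen with compound 3 need not repeat, but a step downward is expected. For compound 4 the expected step is a 3.0-fold lower number from compound 2 to compound 4 (0.48 log units; beyond the scatter) in this assay. Compound 4 is therefore estimated at 5 nM in this assay, with a range from 1.5 nM to 20 nM.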

Compound 4, inhibition constant: 4.66 nM
The estimate for compound 4 lay 1.1-fold (0.03 log units) above the measured number; measured number inside the range.
By their numbers in this assay, from the lowest: compound 3; then compound 4; then compound 2; then compound 1.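

In this assay, a 3.2-fold lower number from compound 2 to compound 4 (0.51 log units; beyond the scatter) shows that the gain on the phenyl ring of compound 2 is not confined to hydroxymethyl: methoxy, with 0 hydrogen-bond donors, on an aromatic carbon para to a large group also gives a step beyond the scatter. Among the compounds shown here, compound 3 and compound 4 differ in more than one place, so no step between them can be read, and these data do not separate the effect of the group from that of its place on the phenyl ring. Nothing at hand bears on the reason for the step to compound 4.

The compounds shown leave open how far this position tolerates other groups, such as an amine, a carboxylic acid or a longer chain like ethoxy, and whether any of these would extend or reverse the step seen with methoxy. They also leave open whether methoxy in the same place would lower the number on compound 1, as the methoxy step is shown only with furan-2-yl on the shared core.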